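Propargyloxy for methoxy on the cinnamoyl side

The source may report more compounds than this note shows. Statements on the series, on what has been measured and on what is new or still open speak of the compounds shown alone.

Measured so far:
compound 1 `C#CCOc1cccc(/C=C/C(=O)Nc2cc(C(=O)c3cc(OC)c(OC)c(OC)c3)ccc2OC)c1`, 15300 nM
compound 2 `COc1cc(C(=O)c2cc(OC)c(OC)c(OC)c2)cc(NC(=O)/C=C/c2cc(OC)c(OC)c(OC)c2)c1OC`, 3900 nM
compound 3 `COc1cccc(/C=C/C(=O)Nc2cc(C(=O)c3cc(OC)c(OC)c(OC)c3)cc(OC)c2OC)c1`, 8600 nM

In a functional assay on ME-180 cells (Homo sapiens) for cytotoxicity, read by MTT assay, with a stated time of 72 h (a higher number here means a weaker inhibitor, a lower number a stronger inhibitor), compound 3 stands second highest of the three numbers; its nearest neighbour is compound 1, within the scatter, and its furthest is compound 2, beyond it. Among the compounds with values here, the one single-point step measured, a 2.2-fold higher number from compound 2 to compound 3 (0.34 log units; beyond the scatter), is modest and concerns the trimethoxyphenyl versus methoxyphenyl end of the chain.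

Compound 4 `C#CCOc1cccc(/C=C/C(=O)Nc2cc(C(=O)c3cc(OC)c(OC)c(OC)c3)cc(OC)c2OC)c1` differs from compound 3 by ethynyl in place of hydrogen on a saturated chain carbon bound to an oxygen on an aromatic ring; cut one bond further out, this reads methoxy to propargyloxy, or 3-methoxyphenyl to 3-(propargyloxy)phenyl. Within the data shown here, no measured step bears directly on this change. Compound 1 carries the same propargyloxy group on a different core and gives 15300 nM, which lies within the scatter of compound 3. Without a direct precedent, compound 4 is expected to move little, if at all, with a 1.3-fold higher number from compound 3 to compound 4 (0.11 log units; within the scatter) as the estimated step. In this assay compound 4 is estimated at 11000 nM, with a range of 5000 nM to 25000 nM.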

Compound 4, half-maximal inhibitory concentration: 8400 nM
Compound 4: middle estimate off by 1.3-fold (0.12 log units), on the high side; low and high end bracket the measured number.
By their numbers in this assay, from the lowest: compound 2; then compounds 4, 3 and 1 (each within the scatter of the next).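

In this assay, within the data shown here, the first direct reading of methoxy to propargyloxy, a 1.0-fold lower number from compound 3 to compound 4 (0.01 log units; within the scatter), shows that ethynyl on a saturated chain carbon bound to an oxygen on an aromatic ring leaves the number unchanged on this core. Against the 3,4,5-trimethoxyphenyl end of compound 2, the 3-(propargyloxy)phenyl end gives a 2.2-fold higher number from compound 2 to compound 4 (0.33 log units; beyond the scatter), a modest step like a 2.2-fold higher number from compound 2 to compound 3 (0.34 log units; beyond the scatter), so both singly substituted ends sit beyond the scatter of compound 2. The other change to the propargyloxy compounds, a 1.8-fold lower number from compound 1 to compound 4 (0.26 log units; within the scatter), stays within the scatter, so methoxy in place of hydrogen on an aromatic carbon shows no clear effect here.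

No supporting measurement accounts for the absence of change at the propargyloxy group. Open, going by these compounds, are whether an amine or a longer chain ending in ethynyl on that oxygen would also leave the number unchanged.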